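Changing the Aromatic Group on a Ring Nitrogen

The source may hold more compounds than are shown below. What is called first, only, known or untested is meant among the compounds shown, and "the series" means these compounds.

Two compounds share one core and differ only in the aromatic group carried on an amine nitrogen in a ring. In a functional assay on CHO cells with adenosine receptor A1 (Homo sapiens) as the target, read by cAMP accumulation and immunoassay, with a stated time of 6 min, tested at 10 uM (a higher number here means a weaker effect of the compound at the concentration tested, a lower number a stronger effect), compound 1 `COc1ccc(N2CCN(Cc3csc(N)c3C(=O)c3ccc(Cl)cc3)CC2)cc1` gives -52%. In this assay compound 2 `Nc1scc(CN2CCN(c3ccc(Cl)c(C(F)(F)F)c3)CC2)c1C(=O)c1ccc(Cl)cc1` gives -60%. Among the measured compounds shown here, compound 2 therefore stands at one of only two measured numbers, and its single neighbour is compound 1; that move, a number 8 percentage points lower from compound 1 to compound 2 (within the scatter), leaves the two compounds indistinguishable on these data.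

Compound 3 `Nc1scc(CN2CCN(c3ccc(OC(F)(F)F)cc3)CC2)c1C(=O)c1ccc(Cl)cc1` has not yet been measured. It differs from compound 2 in one place: 4-(trifluoromethoxy)phenyl in place of 4-chloro-3-(trifluoromethyl)phenyl on an amine nitrogen in a ring. For the measured compounds named here, the only measured step that bears on this is the exchange between compound 1 and compound 2, which also replaced the aromatic group at this same position and stayed within the scatter. With that single precedent, the step from compound 2 to compound 3 is expected to be a number 4 percentage points higher from compound 2 to compound 3 (within the scatter), that is, no change beyond the scatter. Compound 3 is therefore estimated to give -56% in this assay, with a plausible range from -72% to -40%.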

Compound 3, a percentage reported as activity, at one concentration (the size of the read-out at that concentration, not a potency): -74%
Estimate against measurement, compound 3: 18 percentage points above; measured number below the stated range.
By their numbers in this assay, from the lowest: compound 3; then compounds 2 and 1 (each within the scatter of the next).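

The aromatic group on the ring nitrogen can change the read-out after all: the earlier exchange stayed within the scatter, but in this assay putting 4-(trifluoromethoxy)phenyl in place of 4-chloro-3-(trifluoromethyl)phenyl gives a number 14 percentage points lower from compound 2 to compound 3 (beyond the scatter). The clearest comparison is with the 4-methoxyphenyl group, where trifluoromethyl in place of methyl on the oxygen gives a number 22 percentage points lower from compound 1 to compound 3 (beyond the scatter), so this single change on an otherwise identical molecule is enough to separate the two compounds, and compound 3 has the strongest effect of the three at the concentration tested. Nothing shown here accounts for either step.

Three aromatic groups on one core cannot show which feature of the group matters, and the two steps are modest and rest on one concentration in one assay. As far as these compounds go, it remains open how a plain phenyl, a 4-chlorophenyl or a pyridine ring would behave on the same nitrogen, and whether a longer chain on the oxygen, such as ethyl or a 2,2,2-trifluoroethyl group, would continue or reverse the change seen with trifluoromethyl.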